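Carbamoyl on the Phenyl: Weighing Three Stability Readings

This account rests on a few compounds, and the source may have more. Where it says the series, first, only, none or still open, it means among the compounds named here.

Compound 3 `C[C@H](Nc1nc(N)nc(N)c1C#N)c1c(-c2ccccc2)c(=O)n2cc(F)ccc2c1-c1ccccc1` stands highest of the three measured compounds in an ADME assay on microsomes from liver (Homo sapiens), read by LC-MS, using NADPH, with a stated time of 30 min, tested at 1 uM (on this read-out higher numbers stand for a more stable compound and lower numbers for a less stable compound), giving 98%. Compound 1 `C[C@H](Nc1nc(N)nc(N)c1C#N)c1cc2ccc(F)cn2c(=O)c1-c1ccccc1` gives 87%, and compound 2 `Cc1c([C@H](C)Nc2nc(N)nc(N)c2C#N)c(-c2ccccc2)c(=O)n2cc(F)ccc12` gives 80%. The steps of a number 11 percentage points higher from compound 1 to compound 3 (beyond the scatter) and a number 18 percentage points higher from compound 2 to compound 3 (beyond the scatter) are modest gains, while a number 7 percentage points lower from compound 1 to compound 2 (within the scatter) lies within the scatter. Compound 4 `C[C@H](Nc1nc(N)nc(N)c1C#N)c1c(-c2ccccc2)c(=O)n2cc(F)ccc2c1-c1ccc(C(N)=O)cc1` differs from compound 3 by carbamoyl in place of hydrogen on an aromatic carbon. For the measured compounds named here, no measured step alters a group on that phenyl ring, so the measured steps bear on this change only indirectly, and compound 3 already sits close to the top of the scale. A step of a number 6 percentage points lower from compound 3 to compound 4 (within the scatter) is therefore expected, not beyond the scatter. Compound 4 is estimated at 92%, in a range from 78% to 100%.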

Compound 4, percent of the compound remaining: 105%
Estimate against measurement, compound 4: 13 percentage points below, outside the stated range (above it).
By their numbers in this assay, from the lowest: compounds 2 and 1 (each within the scatter of the next); then compounds 3 and 4 (each within the scatter of the next).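

In this assay, the carbamoyl group is the first change shown on the phenyl ring itself, and a number 7 percentage points higher from compound 3 to compound 4 (within the scatter) shows that this ring carbon, para to a large group, takes carbamoyl in place of hydrogen without a step beyond the scatter. With 4-carbamoylphenyl in place of methyl or hydrogen on the core, the readings show a number 25 percentage points higher from compound 2 to compound 4 (beyond the scatter) and a number 18 percentage points higher from compound 1 to compound 4 (beyond the scatter). Nothing measured here explains this result. Going by these compounds, whether an amine, a carboxylic acid or a methyl ester on that same ring carbon would read alike remains open.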